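Methyl to methoxy on the fused ring: expected read-out

The source may report more compounds than this note shows. Statements on the series, on what has been measured and on what is new or still open speak of the compounds shown alone.

Measured compounds in a functional assay on Hep 3B2 cells (Homo sapiens) for antiproliferative activity, read by MTT assay, with a stated time of 24 h, tested at 0.41 ug/mL; on this read-out higher numbers stand for a stronger effect at the one concentration tested and lower numbers for a weaker effect:
compound 1, `CCOc1ccc2nc(C(=O)Nc3c(F)cc(-c4cccc(F)c4)cc3F)c(C)c(O)c2c1`, 0.26%
compound 2, `Cc1ccc2nc(C(=O)Nc3c(F)cc(-c4cccc(F)c4)cc3F)c(C)c(C(=O)O)c2c1`, 15.2%

In this assay compound 2 stands highest of the two numbers measured, and the nearest number, that of compound 1, lies well below it, beyond the scatter. Going by the values given here, compound 1 and compound 2 differ in more than one place, so no single step connects them, and the gap between them can only be read as what the two values show.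

Compound 3, `COc1ccc2nc(C(=O)Nc3c(F)cc(-c4cccc(F)c4)cc3F)c(C)c(C(=O)O)c2c1`, is not yet measured. It differs from compound 2 in one place: methoxy in place of methyl on an aromatic carbon. Among the compounds with values here, with no step between measured compounds available, the size of the change is judged only from the structures. A single added oxygen at that place is a small change, and no step beyond the scatter is expected in either direction.

Compound 3 is therefore expected to give about 13%, with a range from 0% to 30%. The step that this estimate means from compound 2 to compound 3 is a number 2.2 percentage points lower from compound 2 to compound 3 (within the scatter), within the scatter.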

Compound 3, a percentage reported as inhibition, at one concentration (the size of the read-out at that concentration, not a potency): 0.68%
The estimate for compound 3 lay 12.3 percentage points above the measured number; the range from low to high includes it.
By their numbers in this assay, from the lowest: compounds 1 and 3 (each within the scatter of the next); then compound 2.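

Methoxy in place of methyl on the aromatic carbon gives, in this assay, a number 14.5 percentage points lower from compound 2 to compound 3 (beyond the scatter), so this position is not indifferent to the exchange of one heavy atom for two. The rest of compound 2 is unchanged in compound 3, including the carboxylic acid, which places this step at this one carbon, though it rests on a single pair read at a single concentration and gives no measure of potency. Nothing at hand explains the step.

The pair cannot separate the entering oxygen from the greater size of the group: ethyl, with two heavy atoms and no oxygen, would bear on that, while a hydroxy group or an amine on the same carbon would test other replacements for methyl. Also open, as far as these compounds go, is whether the step at this carbon would persist if the carboxylic acid were replaced by another group, and whether a longer chain such as ethoxy would follow methoxy here.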